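This account rests on a few compounds, and the source may have more. Where it says the series, first, only, none or still open, it means among the compounds named here.

In a functional assay on MCF7 cells (Homo sapiens) for inhibition, read by MTT assay, with a stated time of 72 h (on this read-out higher numbers stand for weaker inhibition and lower numbers for stronger inhibition), compound 1 `O=C(Nc1ccccc1)C1CCN(C/C=C/c2ccccc2)CC1` gives 60200 nM, compound 2 `Cc1ccc(NC(=O)C2CCN(C/C=C/c3ccccc3)CC2)cc1` gives 30000 nM and compound 3 `O=C(Nc1cccc(C(F)(F)F)c1)C1CCN(C/C=C/c2ccccc2)CC1` gives 16100 nM. Compound 3 stands apart from compound 1 only. That gap, with trifluoromethyl in place of hydrogen on an aromatic carbon, is a modest one beyond the scatter: a 3.7-fold lower number from compound 1 to compound 3 (0.57 log units; beyond the scatter). The values of compound 3 and compound 2 lie within the scatter of each other. The step with methyl in place of hydrogen on an aromatic carbon also stays within the scatter: a 2.0-fold lower number from compound 1 to compound 2 (0.30 log units; within the scatter).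

Compound 4 `O=C(Nc1cccc(Cl)c1)C1CCN(C/C=C/c2ccccc2)CC1` has not yet been measured. It differs from compound 3 by chloro in place of trifluoromethyl on an aromatic carbon, meta to a large group: chloro in place of trifluoromethyl on an aromatic carbon. Among the compounds with values here, no measured compound carries chloro, so the evidence is indirect. Both measured steps place a group on an aromatic carbon, and neither is large. Exchanging one such group for another is therefore expected to produce little change in this assay. The expected step is a 1.2-fold higher number from compound 3 to compound 4 (0.09 log units; within the scatter), a slightly higher number that stays within the scatter. For compound 4 the estimate is 20000 nM, with an expected range from 9000 nM to 42000 nM.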

Compound 4, half-maximal inhibitory concentration: 16100 nM
For compound 4 the middle estimate is 1.2-fold (0.09 log units) above the measured one; the range from low to high includes it.
By their numbers in this assay, from the lowest: compounds 3, 4, 2 and 1 (each within the scatter of the next, the first and the last beyond it).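

In this assay, the exchange of trifluoromethyl, with its 4 heavy atoms, for chloro, with 1 heavy atom, gives no change at the digits printed from compound 3 to compound 4 (within the scatter), so at this carbon, meta to a large group, the two groups cannot be told apart on this read-out. Compared with the unsubstituted compound, chloro gives a 3.7-fold lower number from compound 1 to compound 4 (0.57 log units; beyond the scatter), which makes it a second group here, after trifluoromethyl, whose step from hydrogen lies beyond the scatter, while the comparison with the methyl compound gives a 1.9-fold lower number from compound 2 to compound 4 (0.27 log units; within the scatter) and so separates the two aryl groups no further. No measurement is available that explains why these two different groups give the same number.

From the compounds shown here alone, what remains open is whether this position accepts only groups like these two, since an amine or a carboxylic acid on the same carbon could give a very different number. Going by these compounds, it is also open whether chloro would give the same result at another carbon of this ring, or whether a longer chain on the ring nitrogen of the shared core would change the picture.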